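Chloro in Place of Methoxy on the Shared Core

A few compounds are considered here, and "the series" means these few. Any claim that something is new, unique, unknown or untested is made for them only; others in the source may bear on it.

Among the compounds with values here, compound 2 `COc1ccc(SC)c(NCC2=NCCN2)c1` gives 91% in a functional assay for agonist activity at Alpha-1D adrenergic receptor (Homo sapiens) (on this read-out lower numbers stand for smaller maximal responses and higher numbers for larger maximal responses), the lower of the two numbers measured so far. Within the data shown here, its only neighbour is compound 1 `CSc1ccc(F)cc1NCC1=NCCN1`, which in this assay gives 107%. Among the measured compounds shown here, the one measured step between them is a number 16 percentage points lower from compound 1 to compound 2 (beyond the scatter). Compound 3 `CSc1ccc(Cl)cc1NCC1=NCCN1` has not yet been measured; its change from compound 2 is chloro in place of methoxy on an aromatic carbon. That single step is the only one that bears on the question. Compound 1 carries fluoro at the position where compound 2 carries methoxy and compound 3 carries chloro, so compound 3 stands nearer to compound 1 than compound 2 does in that respect. Given a number 16 percentage points lower from compound 1 to compound 2 (beyond the scatter), exchanging the methoxy for chloro is expected to move the number back up, though no chloro analogue has been measured and the expectation rests on one step alone. Compound 3 is therefore expected to show the step of a number 9 percentage points higher from compound 2 to compound 3 (within the scatter) in this assay. The estimate for compound 3 is 100%, within a range from 85% to 115%.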

Compound 3, largest response reached (reported as maximum), in percent of the reference or control that the assay uses: 106%
Estimate against measurement, compound 3: 6 percentage points below; low and high end bracket the measured number.
By their numbers in this assay, from the lowest: compound 2; then compounds 3 and 1 (each within the scatter of the next).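

In this assay, the position para to a methylsulfanyl group can now be read with three different groups, and the exchange of methoxy for chloro gives a number 15 percentage points higher from compound 2 to compound 3 (beyond the scatter), while the exchange of fluoro for chloro gives a number 1 percentage points lower from compound 1 to compound 3 (within the scatter). Fluoro and chloro therefore cannot be told apart on this read-out, and methoxy stands alone with the smaller maximal response, which the single step between compound 1 and compound 2 could not show. Nothing in the data given accounts for this difference between methoxy and the two halogens.

The compounds shown leave open whether other groups at this position, such as bromo, methyl, an amine or the longer ethoxy chain, would side with the halogens or with methoxy. They also leave open whether the gap between methoxy and the halogens would persist if the methylsulfanyl group were replaced by another group, such as methoxy or ethyl, as compound 1, compound 2 and compound 3 all carry it.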